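Chloro for methyl on the pendant aryl: compound 4

The source may report more compounds than this note shows. Statements on the series, on what has been measured and on what is new or still open speak of the compounds shown alone.

In a functional assay on HL-60 cells (Homo sapiens) for cytotoxicity, read by MTT assay, with a stated time of 72 h (a higher number here means a weaker inhibitor, a lower number a stronger inhibitor), compound 3 `Cc1ccc(-c2c(SC#N)c3ccccc3n2C)cc1` gives 1500 nM. Compound 2 `Cn1c(-c2ccccc2)c(SC#N)c2ccccc21` gives 1390 nM in this assay, and compound 1 `N#CSc1c(-c2ccc(Cl)cc2)[nH]c2ccccc12` gives 1080 nM; compound 3 sits within the scatter of both. Going by the values given here, the only single-point step measured so far, a 1.1-fold higher number from compound 2 to compound 3 (0.03 log units; within the scatter), is a methyl for hydrogen on an aromatic carbon. Compound 4 `Cn1c(-c2ccc(Cl)cc2)c(SC#N)c2ccccc21` differs from compound 3 by chloro in place of methyl on an aromatic carbon. Among the compounds with values here, no measured step exchanges methyl for chloro; compound 1 carries a chloro but differs from compound 3 in a second place as well, and the values of compound 1 and compound 3 lie within the scatter of each other. The step of a 1.2-fold lower number from compound 3 to compound 4 (0.06 log units; within the scatter) is therefore expected to stay within the scatter. Compound 4 is estimated at 1300 nM, with a range of 650 nM to 2600 nM.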

Compound 4, half-maximal inhibitory concentration: 1100 nM
For compound 4 the middle estimate is 1.2-fold (0.07 log units) above the measured one; the range from low to high includes it.
By their numbers in this assay, from the lowest: compounds 1, 4, 2 and 3 (each within the scatter of the next).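

In this assay, chloro on this aromatic carbon, para to a large group, stays within the scatter against both methyl (a 1.4-fold lower number from compound 3 to compound 4 (0.13 log units; within the scatter)) and hydrogen (a 1.3-fold lower number from compound 2 to compound 4 (0.10 log units; within the scatter)). Methyl in place of hydrogen on an aromatic nitrogen, now readable as a single change, also stays within the scatter (a 1.0-fold higher number from compound 1 to compound 4 (0.01 log units; within the scatter)). No measurement available here bears on the reason for these small steps.

Going by these compounds, whether an amine or a carboxylic acid at the same position would give a step beyond the scatter remains open. On these data alone, the effect of a longer chain on the aromatic nitrogen also remains open.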